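The compounds below may be only part of what the source reports. "The series", "measured", "known", "first", "only" and "open" are said of these compounds alone.

Working notes on the series. Compound 1 (`COc1ccc(-c2cc(=O)c3c(OC)cc(OC)cc3n2S(=O)(=O)c2cccc([N+](=O)[O-])c2)cc1`) and compound 2 (`COc1ccc(-c2cc(=O)c3c(OC)cc(OC)cc3n2S(=O)(=O)c2cccc(Br)c2)cc1`) share one core and differ only in the group on the sulfonyl. In a functional assay on KOPN-8 cells (Homo sapiens) for antiproliferative activity, with a stated time of 72 h (a lower number here means that less compound is needed, a higher number that more compound is needed for the effect), compound 1 reaches only the limit of the assay at > 39600 nM. In this assay compound 2 likewise reaches only the limit of the assay at > 58600 nM. The step that the two limits leave unreadable from compound 1 to compound 2 therefore cannot be read in size or direction, as both values are limits (the limit of > 39600 nM in this assay, at which 1 of the 2 values shown sits, (the limit of > 58600 nM in this assay, at which 1 of the 2 values shown sits)). Compound 2 thus stands at a limit, not at a number, and nothing places it above or below compound 1.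

Compound 3 (`COc1ccc(-c2cc(=O)c3c(OC)cc(OC)cc3n2S(=O)(=O)c2ccc(OC)cc2)cc1`) is not yet measured. The change is 4-methoxyphenyl in place of 3-bromophenyl on a sulfonyl sulfur. Going by the values given here, the only measured step on this part of the structure, a step that the two limits leave unreadable from compound 1 to compound 2, is unreadable, so no size or direction beyond the scatter can be drawn from it. Compound 3 is expected to remain near the limits of its two neighbours, with the step of an at least 1.1-fold lower number from compound 2 to compound 3 (0.06 log units; that floor lies within the scatter) taken as an estimate without a readable precedent. The estimate for compound 3 in this assay is 50000 nM, ranging from 8000 nM to 200000 nM.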

Compound 3, half-maximal effective concentration: > 82700 nM
Compound 3: no number, only a limit; the forecaster's own chance of this, stated with the estimate: 80%; middle value at least 1.6-fold (0.21 log units) away from the limit.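

In this assay, going by these compounds alone, compound 3 gives only a limit, > 82700 nM, so no step among compound 1, compound 2 and compound 3 can be read in size or direction. The compounds shown leave open what number each would reach, and whether the group on the sulfonyl matters at all.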